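Dropping the Para Substituent: Expected Lipophilicity of Compound 3

This account rests on a few compounds, and the source may have more. Where it says the series, first, only, none or still open, it means among the compounds named here.

Compound 1, `CNc1nc(NCCCN(C)C)c2sc(-c3ccc(S(C)(=O)=O)cc3)cc2n1`, in a physicochemical assay for lipophilicity, read by HPLC, at pH 7.4 (a lower number here means a more polar compound, a higher number a more lipophilic compound), compound 1 gives 2.1.
Compound 2, `CNc1nc(NCCCN(C)C)c2sc(-c3ccc(N4CCNCC4)cc3)cc2n1`, in this assay compound 2 gives 3.5.

Within the data shown here, compound 2 stands highest of the two measured numbers; the only neighbour is compound 1, which sits lower by the measured step. Among the measured compounds shown here, that step, a number 1.40 log units higher from compound 1 to compound 2 (beyond the scatter), is the single measured comparison, and it exchanges one substituent for another at the same aromatic carbon.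

Compound 3, `CNc1nc(NCCCN(C)C)c2sc(-c3ccccc3)cc2n1`, differs from compound 2 by hydrogen in place of piperazin-1-yl on an aromatic carbon. Here the substituent is not exchanged but removed outright, so no measured step covers the same kind of change. The measured step only shows that what sits on this aromatic carbon can move the read-out by a large amount, and it gives no direction for a bare ring. Taken together, a moderate rise from compound 2 to compound 3 is expected, a number 0.30 log units higher from compound 2 to compound 3 (within the scatter), though with wide uncertainty.

Compound 3 is therefore estimated at 3.8, within a range from 3 to 4.6.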

Compound 3, distribution coefficient: 2.2
Compound 3: the middle estimate sits 1.60 log units above what was measured; the whole stated range lies above it.
By their numbers in this assay, from the lowest: compounds 1 and 3 (each within the scatter of the next); then compound 2.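

In this assay, hydrogen in place of piperazin-1-yl on this aromatic carbon gives a number 1.30 log units lower from compound 2 to compound 3 (beyond the scatter), a change as large as the one first seen between the two substituents. Hydrogen in place of methylsulfonyl gives a number 0.10 log units higher from compound 1 to compound 3 (within the scatter), so the bare ring and the methylsulfonyl compound cannot be told apart in this read-out. The earlier step could not show which of the two groups stood away from an unsubstituted ring, but with hydrogen as the reference point, compound 2 alone stands apart among these three compounds, and the large gap lies on the piperazin-1-yl side.

On these data alone, it remains open which part of piperazin-1-yl goes with the higher number, and whether a morpholine ring, a piperidine ring, a simple amine or a carboxylic acid on the same carbon would fall with compound 2 or with the other two compounds. No measurement shown here accounts for why piperazin-1-yl stands apart from hydrogen and methylsulfonyl on this carbon.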